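The source may report more compounds than this note shows. Statements on the series, on what has been measured and on what is new or still open speak of the compounds shown alone.

Working notes on the series. Compound 1 `CCCCOC1=C(C(=O)c2ccccc2)C(c2ccc(Br)cc2)N(CCCn2ccnc2)C1=O` gives, in a functional assay on NCI-H1299 cells (Homo sapiens) for antiproliferative activity, read by MTT assay, with a stated time of 72 h (on this read-out lower numbers stand for stronger inhibition and higher numbers for weaker inhibition), a value of 17100 nM. Compound 2 `O=C(C1=C(Nc2ccc(Br)cc2)C(=O)N(CCCn2ccnc2)C1c1ccc(Br)cc1)c1ccccc1` gives 19300 nM in this assay. Within the data shown here, the step of a 1.1-fold higher number from compound 1 to compound 2 (0.05 log units; within the scatter) leaves the two values within the scatter of each other, so on the numbers so far compound 1 stands beside compound 2 rather than apart from it.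

Compound 3 `O=C(C1=C(Nc2cccc(Br)c2)C(=O)N(CCCn2ccnc2)C1c1ccc(Br)cc1)c1ccccc1` is to be measured in this assay. It differs from compound 1 in one place: (3-bromophenyl)amino in place of butoxy on a double-bonded ring carbon. Among the measured compounds shown here, the only measured step that bears on this is a 1.1-fold higher number from compound 1 to compound 2 (0.05 log units; within the scatter), in which the same butoxy was replaced at the same place by a bromophenylamino group and no step beyond the scatter followed. The expectation for compound 3 is therefore a step of a 1.1-fold higher number from compound 1 to compound 3 (0.02 log units; within the scatter), that is none beyond the scatter. The estimate for compound 3 in this assay is 18000 nM, within a range of 9000 nM to 36000 nM.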

Compound 3, half-maximal inhibitory concentration: 11500 nM
The estimate for compound 3 lay 1.6-fold (0.19 log units) above the measured number; measured number inside the range.
By their numbers in this assay, from the lowest: compounds 3, 1 and 2 (each within the scatter of the next).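

The step of a 1.5-fold lower number from compound 1 to compound 3 (0.17 log units; within the scatter) stays within the scatter, so a second bromophenylamino group at this double-bonded ring carbon also stands level with butoxy in this assay, even with the aromatic ring and hydrogen-bond donor that enter with it. The step of a 1.7-fold lower number from compound 2 to compound 3 (0.22 log units; within the scatter) is also within the scatter, so 3-bromophenyl and 4-bromophenyl on the amine nitrogen cannot be told apart on these numbers. No evidence at hand accounts for this flat picture.

The compounds shown leave open whether a phenylamino group without bromine or a 2-bromophenylamino group would stay level with these three. They also leave open whether a smaller group at this ring carbon, such as methoxy or a simple alkylamine, or a carboxylic acid on a longer chain, would give a step beyond the scatter.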